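Furan-to-thiophene exchange on two fused-ring cores

The compounds below may be only part of what the source reports. "The series", "measured", "known", "first", "only" and "open" are said of these compounds alone.

Measured so far:
compound 1 `O=c1[nH]cnc2c1c(-c1ccoc1)cn2[C@@H]1O[C@H](CO)[C@@H](O)[C@H]1O` — 14500 nM
compound 2 `COc1ncnc2c1c(-c1ccoc1)cn2[C@@H]1O[C@H](CO)[C@@H](O)[C@H]1O` — 2820 nM
compound 3 `O=c1[nH]cnc2c1c(-c1cccs1)cn2[C@@H]1O[C@H](CO)[C@@H](O)[C@H]1O` — a limit only, > 20000 nM

All three were run in a functional assay on K562 cells (Homo sapiens), read by MTT assay, with a stated time of 72 h; on this read-out lower numbers stand for stronger inhibition and higher numbers for weaker inhibition. Compound 2 has the lowest of the two numbers, and the gap to compound 1 is beyond the scatter; the difference between the two cores of compound 1 and compound 2 is not broken down here.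

One change recurs. Made on the core of compound 1, it is thiophen-2-yl in place of furan-3-yl on an aromatic carbon and gives an at least 1.3-fold higher number from compound 1 to compound 3 (0.13 log units; that floor lies within the scatter). Compound 3 sits at the limit of > 20000 nM in this assay, at which 1 of the 3 values shown sits, so the size of that step is only a floor.

Compound 4 `COc1ncnc2c1c(-c1cccs1)cn2[C@@H]1O[C@H](CO)[C@@H](O)[C@H]1O` has not yet been measured. It carries the same change on the core of compound 2, (thiophen-2-yl in place of furan-3-yl on an aromatic carbon), at a place described in the same words as before. Starting from compound 2, a step of a 2.5-fold higher number from compound 2 to compound 4 (0.39 log units; beyond the scatter) is expected, resting on an at least 1.3-fold higher number from compound 1 to compound 3 (0.13 log units; that floor lies within the scatter). Compound 4 is therefore estimated at 7000 nM, plausibly between 3000 nM and 20000 nM, with a fair chance that this assay returns only a limit.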

Compound 4, half-maximal inhibitory concentration: 6200 nM
Compound 4: middle estimate off by 1.1-fold (0.05 log units), on the high side; low and high end bracket the measured number.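

On the core of compound 2, thiophen-2-yl in place of furan-3-yl on an aromatic carbon gives a 2.2-fold higher number from compound 2 to compound 4 (0.34 log units; beyond the scatter) in this assay, a modest loss of inhibition that can be read as a full step. Set beside the same change on the core of compound 1, the comparison reads: the same change on two cores in this assay, an at least 1.3-fold higher number (0.13 log units; that floor lies within the scatter) from compound 1 to compound 3 and a 2.2-fold higher number (0.34 log units; beyond the scatter) from compound 2 to compound 4; the limit leaves it open whether they differ Compound 3 stands only as a limit, > 20000 nM, so this pair shows a change that can be followed on the core of compound 2, but it does not show that the step has the same size on both cores, and two cores support no rule for the series.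

The change swaps the hetero atom and the point of attachment together, so furan-2-yl or thiophen-3-yl would be needed to read these two apart on either core. On these data alone, how an amine or a longer chain would read at the same place also remains open.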